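Swapping the Side Group of Compound 3 for Benzoyl

This account rests on a few compounds, and the source may have more. Where it says the series, first, only, none or still open, it means among the compounds named here.

Measured so far in a functional assay on the whole organism (strain albino) for inhibition, with Rattus norvegicus as the target, read by paw edema, with a stated time of 4 h, at a dose of 0.28 mmol/kg by the oral route; on this read-out higher numbers stand for more inhibition at the one dose given (going by the name of the read-out) and lower numbers for less inhibition:
compound 1, `CCn1c(SCC(=O)c2ccccc2)nnc1-c1cc(OC)c(OC)c(OC)c1`, gives 72%
compound 2, `CCn1c(SC/C(=N/O)c2ccccc2)nnc1-c1cc(OC)c(OC)c(OC)c1`, gives 79%
compound 3, `COc1cc(-c2nnc(SC/C(=N/O)c3ccccc3)n2-c2ccccc2)cc(OC)c1OC`, gives 76%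

On these three numbers compound 3 stands second highest. Its nearest neighbour is compound 2, as shown by the step of a number 3 percentage points lower from compound 2 to compound 3 (within the scatter); its furthest is compound 1, whose value sits a little lower but still within the scatter of the value of compound 3.

Compound 4, `COc1cc(-c2nnc(SCC(=O)c3ccccc3)n2-c2ccccc2)cc(OC)c1OC`, differs from compound 3 in one place: a group of 8 heavy atoms (7 carbon, 1 oxygen; one six-membered aromatic ring of carbon only) in place of a group of 9 heavy atoms (7 carbon, 1 nitrogen, 1 oxygen; one six-membered aromatic ring of carbon only), on a saturated chain carbon bound to a sulfur. For the measured compounds named here, the only measured step that bears on this change is its mirror image, a number 7 percentage points higher from compound 1 to compound 2 (within the scatter), a shift within the scatter. Running the same swap the other way is therefore expected to shift the number by a number 6 percentage points lower from compound 3 to compound 4 (within the scatter), downward but not beyond the scatter. Compound 4 is estimated at 70%, with a range from 58% to 82%.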

Compound 4, a percentage reported as inhibition, in the whole organism at one dose (the size of the read-out at that dose, not a potency): 73%
The estimate for compound 4 lay 3 percentage points below the measured number; measured number inside the range.
By their numbers in this assay, from the lowest: compounds 1, 4, 3 and 2 (each within the scatter of the next).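

Each of the two changes can now be read on two cores. With benzoyl on a saturated chain carbon bound to a sulfur, the step is a number 3 percentage points lower from compound 3 to compound 4 (within the scatter), and this swap reads alike on both cores: the same change on two cores in this assay, a number 7 percentage points higher (within the scatter) from compound 1 to compound 2 and a number 3 percentage points higher (within the scatter) from compound 4 to compound 3, 4 percentage points apart, within the scatter of two such steps Phenyl in place of ethyl on an aromatic nitrogen gives a number 1 percentage points higher from compound 1 to compound 4 (within the scatter), and it too reads alike on both cores: the same change on two cores in this assay, a number 3 percentage points lower (within the scatter) from compound 2 to compound 3 and a number 1 percentage points higher (within the scatter) from compound 1 to compound 4, 4 percentage points apart, within the scatter of two such steps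

No step here lies beyond the scatter, so neither change is shown to alter the read-out. From the compounds shown here alone, how an amine, a carboxylic acid or a longer chain on that chain carbon would read remains open.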